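A few compounds are considered here, and "the series" means these few. Any claim that something is new, unique, unknown or untested is made for them only; others in the source may bear on it.

Measured in a functional assay (brain) for inhibition, with Rattus norvegicus as the target; on this read-out lower numbers stand for stronger inhibition and higher numbers for weaker inhibition:
- compound 1 `CCCCCCCCCOC1=C(O)OC(C(O)CO)C1=O`: 0.027 nM
- compound 2 `CCCCCCCCCCCCCOC1=C(O)OC(C(O)CO)C1=O`: 7400 nM
- compound 3 `CCCCCCCCCCCCCCCCCCOC1=C(O)[C@@H](C(O)CO)OC1=O`: 4300 nM

Compound 2 sits at the weak end of these numbers together with compound 3, the two lying within the scatter of each other and both far from compound 1.

The next compound is compound 4 `CCCCCCCCCCCCCCCCCCCCOC1=C(O)OC(C(O)CO)C1=O`, which differs from compound 2 by heptyl in place of hydrogen on a saturated chain carbon, ten or more bonds along the chain from an oxygen on an unsaturated carbon. For the measured compounds named here, only one measured step bears on this change: a 270000-fold higher number from compound 1 to compound 2 (5.44 log units; beyond the scatter), also an extension of the chain on a saturated carbon, and large. One step gives no basis for expecting a repeat of that size in this assay. Going by the values given here, compound 3 at 4300 nM shows the only other number in this region, and it lies with compound 2. No further step beyond the scatter is therefore expected, though with little certainty. The estimated step is a 1.1-fold higher number from compound 2 to compound 4 (0.03 log units; within the scatter). For compound 4 the expected value is 8000 nM, with an estimated range of 2000 nM to 35000 nM.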

Compound 4, half-maximal inhibitory concentration: 4700 nM
Compound 4: the middle estimate sits 1.7-fold (0.23 log units) above what was measured; measured number inside the range.
By their numbers in this assay, from the lowest: compound 1; then compounds 3, 4 and 2 (each within the scatter of the next).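

In this assay, heptyl in place of hydrogen on a saturated chain carbon, ten or more bonds along the chain from an oxygen on an unsaturated carbon, gives a 1.6-fold lower number from compound 2 to compound 4 (0.20 log units; within the scatter). The large earlier change, a 270000-fold higher number from compound 1 to compound 2 (5.44 log units; beyond the scatter), is therefore not repeated at this position: across compounds 1, 2 and 4, the number does not keep rising as the chain grows, but stays level from compound 2 onward. Nothing at hand accounts for either the large step or the absence of a further one.

Chains of intermediate length between those of compound 1 and compound 2 would be needed to show whether the large step is abrupt or gradual, and chains shorter than that of compound 1 remain unplaced. As far as these compounds go, how an amine or a carboxylic acid on the chain would read out also stays open.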